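The source may hold more compounds than are shown below. What is called first, only, known or untested is meant among the compounds shown, and "the series" means these compounds.

Compound 1 `COc1cc(-c2nnc3n2NC(c2ccco2)C(C(=O)c2cccs2)S3)cc(OC)c1OC`: in a functional assay on HepG2 cells (Homo sapiens) for cytotoxicity, read by MTT assay, with a stated time of 48 h (on this read-out higher numbers stand for weaker inhibition and lower numbers for stronger inhibition), compound 1 gives 64100 nM.
Compound 2 `COc1cc(-c2nnc3n2NC(c2ccco2)C(C(=O)c2ccc(F)cc2)S3)cc(OC)c1OC`: in this assay compound 2 gives > 100000 nM, which is a limit of the assay and not a number.

Going by the values given here, compound 1 holds the only number among the two values shown; the other value is a limit (the limit of > 100000 nM in this assay, at which 1 of the 2 values shown sits). The compound to be measured is compound 3 `COc1cc(-c2nnc3n2NC(c2ccco2)C(C(=O)c2cccc(Br)c2)S3)cc(OC)c1OC`. It differs from compound 1 in one place: 3-bromophenyl in place of thiophen-2-yl on a carbonyl carbon. Among the compounds with values here, the one measured step at the same place is the one from compound 1 to compound 2, where a 4-fluorophenyl replaced the thiophen-2-yl on the carbonyl carbon; it gave an at least 1.5-fold higher number from compound 1 to compound 2 (0.19 log units; that floor lies within the scatter). That step rests on a limit, so it sets only a floor, and that floor lies within the usual scatter. On this basis a ring of carbon only in place of the thiophen-2-yl is expected to leave this assay about where compound 1 stands or to push it somewhat weaker, with a real chance that only a limit is reported. Compound 3 is therefore estimated at 90000 nM, within 40000 nM to 200000 nM, a step of a 1.4-fold higher number from compound 1 to compound 3 (0.15 log units; within the scatter).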

Compound 3, half-maximal inhibitory concentration: > 100000 nM
Compound 3 gave a limit, no number; the forecaster's own chance of this, stated with the estimate: 45%; at least 1.1-fold (0.04 log units) between middle value and limit.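

In this assay, 3-bromophenyl in place of thiophen-2-yl on the carbonyl carbon gives an at least 1.5-fold higher number from compound 1 to compound 3 (0.19 log units; that floor lies within the scatter), so a floor of this size does not by itself establish a real loss. What compound 3 adds is a second six-membered aromatic ring of carbon only at this position that ends without a number, which leaves compound 1, with its thiophen-2-yl, as the only compound shown to give one, and the two carbon-only rings both stop at the same limit: the limit of > 100000 nM in this assay, at which 2 of the 3 values shown sit. The step from compound 2 to compound 3 cannot be read, so 3-bromophenyl and 4-fluorophenyl cannot be ranked against each other.

Going by these compounds, how far the true values of compound 2 and compound 3 lie from that of compound 1 remains open, and with it whether either gap goes beyond the usual scatter. Also open, on these data alone, is how this assay responds when the thiophen-2-yl on the carbonyl carbon gives way to an amine, a carboxylic acid or a longer alkyl chain, or to a furan-2-yl ring.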